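Adding a Third Methoxy Group to the Weakest Compound

The source may report more compounds than this note shows. Statements on the series, on what has been measured and on what is new or still open speak of the compounds shown alone.

Measured compounds:
compound 1 `CSc1nc(NCCCCNc2ccnc3cc(Cl)ccc23)c(C#N)c(-c2ccccc2)n1` 5200 nM
compound 2 `CSc1nc(NCCCCNc2ccnc3cc(Cl)ccc23)c(C#N)c(-c2ccc([N+](=O)[O-])cc2)n1` 760 nM
compound 3 `COc1ccc(-c2nc(SC)nc(NCCCCNc3ccnc4cc(Cl)ccc34)c2C#N)cc1OC` 16000 nM

All three compounds share one core and differ only in the aromatic ring attached to it. In an ADME assay on CCRF-CEM cells (Homo sapiens) for inhibition, read by cell counting (on this read-out higher numbers stand for weaker inhibition and lower numbers for stronger inhibition), compound 1 gives 5200 nM, compound 2 gives 760 nM and compound 3 gives 16000 nM. Compound 3 stands at the highest number of the three: the step of a 3.1-fold higher number from compound 1 to compound 3 (0.49 log units; beyond the scatter) and the step of a 21-fold higher number from compound 2 to compound 3 (1.32 log units; beyond the scatter) are both beyond the scatter, so compound 3 is the weakest inhibitor measured here. For comparison, the step of a 6.8-fold lower number from compound 1 to compound 2 (0.84 log units; beyond the scatter) shows how much a single substituent on that ring can shift the number.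

Compound 4 `COc1cc(-c2nc(SC)nc(NCCCCNc3ccnc4cc(Cl)ccc34)c2C#N)cc(OC)c1OC` has not yet been measured. It differs from compound 3 by methoxy in place of hydrogen on an aromatic carbon. Among the compounds with values here, none of the measured steps adds a methoxy group to a ring that already carries two, so they bear on this change only loosely: both changes away from plain phenyl moved the number beyond the scatter, in opposite directions. Within the data shown here, the nearest precedent is the step from compound 1 to compound 3, where methoxy groups raised the number. The expectation is therefore a step of a 1.3-fold higher number from compound 3 to compound 4 (0.10 log units; within the scatter), small and uncertain in direction. Compound 4 is estimated at 20000 nM, with a range from 6000 nM to 60000 nM.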

Compound 4, half-maximal inhibitory concentration: 3600 nM
Compound 4: middle estimate off by 5.6-fold (0.74 log units), on the high side, and the stated range ends above it.
By their numbers in this assay, from the lowest: compound 2; then compounds 4 and 1 (each within the scatter of the next); then compound 3.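

In this assay, the third methoxy group does not extend the earlier rise (a 3.1-fold higher number from compound 1 to compound 3 (0.49 log units; beyond the scatter)) but reverses it (a 4.4-fold lower number from compound 3 to compound 4 (0.65 log units; beyond the scatter)), so at this ring the effect of methoxy groups does not simply build with each one added. The 3,4,5-trimethoxyphenyl ring instead brings the number back level with that of plain phenyl (a 1.4-fold lower number from compound 1 to compound 4 (0.16 log units; within the scatter)), a step within the scatter, while the 4-nitrophenyl ring still gives the stronger inhibition (a 4.7-fold higher number from compound 2 to compound 4 (0.68 log units; beyond the scatter)). Nothing shown here accounts for why adding this one group changes the number in this way.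

The compounds shown leave open whether the recovery depends on methoxy itself or would also appear with another group at the same ring carbon, such as an ethoxy group, an amine or a hydroxyl group. Within the data shown here, they also leave open whether the same step would hold on a ring carrying only one methoxy group, so the reversal rests on this single pair, compound 3 and compound 4.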